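Working notes on amine variants of the shared core

The source may hold more compounds than are shown below. What is called first, only, known or untested is meant among the compounds shown, and "the series" means these compounds.

Compound 1 `O=C1C(NC2CCCC2)=CC(=O)c2c1nc1n2[C@H]2OC[C@@H](O)[C@H]2OC1`: in a functional assay on HeLa cells (Homo sapiens) for inhibition, read by sulforhodamine B assay (a higher number here means a weaker inhibitor, a lower number a stronger inhibitor), compound 1 gives only a limit, > 16000 nM.
Compound 2 `O=C1C(NC2CCCCC2)=CC(=O)c2c1nc1n2[C@H]2OC[C@@H](O)[C@H]2OC1`: in this assay compound 2 gives only a limit, > 16000 nM.
Compound 3 `O=C1C(N2CCCC2)=CC(=O)c2c1nc1n2[C@H]2OC[C@@H](O)[C@H]2OC1`: in this assay compound 3 gives only a limit, > 16000 nM.

Compound 3 thus stands at the limit, as do the other two (the limit of > 16000 nM in this assay, at which 3 of the 3 values shown sit). The measured steps, a step that the two limits leave unreadable from compound 1 to compound 2, a step that the two limits leave unreadable from compound 1 to compound 3 and a step that the two limits leave unreadable from compound 2 to compound 3, give no readable size in either direction. Compound 4 `O=C1C(Nc2ccccc2F)=CC(=O)c2c1nc1n2[C@H]2OC[C@@H](O)[C@H]2OC1` differs from compound 3 by (2-fluorophenyl)amino in place of pyrrolidin-1-yl on a double-bonded ring carbon. For the measured compounds named here, none of the measured steps covers an aromatic amine in this place, and none has a readable size, so no direction can be drawn from them. Compound 4 is therefore expected to remain near the limit, the estimated step that the limit leaves unreadable from compound 3 to compound 4 carrying no supported direction. The estimate for compound 4 in this assay is 20000 nM, within 5000 nM to 80000 nM, most likely reported again only as a limit.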

Compound 4, half-maximal inhibitory concentration: 9820 nM
Compound 4: middle estimate off by 2.0-fold (0.31 log units), on the high side; the range from low to high includes it.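

For the compounds shown here, on the double-bonded ring carbon, (2-fluorophenyl)amino gives compound 4 the first value in this assay that is a number and not a limit, with an at least 1.6-fold lower number from compound 3 to compound 4 (0.21 log units; that floor lies within the scatter), an at least 1.6-fold lower number from compound 2 to compound 4 (0.21 log units; that floor lies within the scatter) and an at least 1.6-fold lower number from compound 1 to compound 4 (0.21 log units; that floor lies within the scatter). Each of these steps is only a floor, so compound 4 is not shown to be a stronger inhibitor than the other three. The steps among compound 1, compound 2 and compound 3 still cannot be read, and one limit covers most of the series: the limit of > 16000 nM in this assay, at which 3 of the 4 values shown sit.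

Whether the fluorine matters, or the aromatic ring alone, stays open, since phenylamino without fluorine does not stand among the compounds shown. As far as these compounds go, how a benzylamino group would read at this place is also open.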